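Chloro to bromo on the pendant phenyl ring of compound 2

The source may report more compounds than this note shows. Statements on the series, on what has been measured and on what is new or still open speak of the compounds shown alone.

Compound 1 `COc1ccc(-c2cn(/N=C/c3cc4ccccc4nc3Cl)c(N)n2)cc1`: > 50000 nM in a functional assay on DLD-1 cells (Homo sapiens) for cytotoxicity, read by MTT assay, with a stated time of 48 h; on this read-out higher numbers stand for weaker inhibition and lower numbers for stronger inhibition
Compound 2 `Nc1nc(-c2ccc(Cl)cc2)cn1/N=C/c1cc2ccccc2nc1Cl`: > 50000 nM in this assay

In this assay compound 1 reaches only a limit, > 50000 nM. Compound 2 likewise reaches only a limit, > 50000 nM. The step that the two limits leave unreadable from compound 1 to compound 2 therefore cannot be sized, and compound 2 stands where compound 1 stands: at the limit, with no number of its own, as noted in the limit of > 50000 nM in this assay, at which 2 of the 2 values shown sit.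

Compound 3 `Nc1nc(-c2ccc(Br)cc2)cn1/N=C/c1cc2ccccc2nc1Cl` differs from compound 2 by bromo in place of chloro on an aromatic carbon. Among the measured compounds shown here, the one measured step, from compound 1 to compound 2, is itself unreadable, so no measured step bears on this change with a size. With both known values sitting at the limit, compound 3 is expected to give a step that the limit leaves unreadable from compound 2 to compound 3 that stays within the scatter. The estimate for compound 3 in this assay is 60000 nM, in a range from 20000 nM to 200000 nM, most likely reported again as a limit.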

Compound 3, half-maximal inhibitory concentration: 23900 nM
For compound 3 the middle estimate is 2.5-fold (0.40 log units) above the measured one; measured number inside the range.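

Among the compounds shown here, replacing 4-chlorophenyl with 4-bromophenyl gives an at least 2.0-fold lower number from compound 2 to compound 3 (0.32 log units; beyond the scatter) in this assay, the first sign that a change at this place on the pendant phenyl ring can bring the read-out off its limit. Bromo in place of methoxy on the same carbon gives an at least 2.0-fold lower number from compound 1 to compound 3 (0.32 log units; beyond the scatter), so the same ring position yields a readable number with bromo but not with either of the other two groups. Compound 3 is therefore the only compound here with a number of its own: the limit of > 50000 nM in this assay, at which 2 of the 3 values shown sit.

From the compounds shown here alone, both steps are known only as bounds, and the step between the two limits cannot be read, so their true sizes stay open. Whether iodo, trifluoromethyl or a nitrile on this carbon would also leave the limit, and how far, remains an open question.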